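A few compounds are considered here, and "the series" means these few. Any claim that something is new, unique, unknown or untested is made for them only; others in the source may bear on it.

Measured in a functional assay on WM 266-4 cells (Homo sapiens) for antiproliferative activity, read by MTT assay, with a stated time of 24 h; on this read-out lower numbers stand for stronger inhibition of growth and higher numbers for weaker inhibition of growth:
- Compound 1 `c1ccc(N2N=C(c3ccc4c(c3)OCCO4)CC2c2ccco2)cc1`: > 100000 nM, a limit
- Compound 2 `Ic1ccc(C2CC(c3ccc4c(c3)OCCO4)=NN2c2ccccc2)cc1`: 3470 nM
- Compound 3 `COc1ccc(C2CC(c3ccc4c(c3)OCCO4)=NN2c2ccccc2)cc1`: > 100000 nM, a limit

Compound 3 stands at the limit of > 100000 nM in this assay, at which 2 of the 3 values shown sit, so its true value is not known. Compound 4 `Clc1cccc(C2CC(c3ccc4c(c3)OCCO4)=NN2c2ccccc2)c1` has 3-chlorophenyl in place of 4-methoxyphenyl on a saturated ring carbon. Among the measured compounds shown here, two measured steps bear on this change. Methoxy in place of iodo gave an at least 28-fold higher number from compound 2 to compound 3 (1.45 log units; beyond the scatter), and 4-iodophenyl in place of furan-2-yl gave an at least 28-fold lower number from compound 1 to compound 2 (1.45 log units; beyond the scatter). Both are large, but 3-chlorophenyl is not 4-iodophenyl, so only part of that gain is expected to carry over. The expected step is an at least 6.6-fold lower number from compound 3 to compound 4 (0.82 log units; beyond the scatter), towards a lower number. For compound 4 the estimated value is 15000 nM, with an expected range of 3000 nM to 80000 nM.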

Compound 4, concentration for 50% growth inhibition: 1750 nM
For compound 4 the middle estimate is 8.6-fold (0.93 log units) above the measured one; measured number below the stated range.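

Putting 3-chlorophenyl on this saturated ring carbon gives an at least 57-fold lower number from compound 3 to compound 4 (1.75 log units; beyond the scatter), and an at least 57-fold lower number from compound 1 to compound 4 (1.75 log units; beyond the scatter). Measurable growth inhibition is thus not tied to 4-iodophenyl: the swap gives a 2.0-fold lower number from compound 2 to compound 4 (0.30 log units; within the scatter), so these two halogen-bearing phenyl groups cannot be told apart here. The two large steps start from limits, so their true size is unknown: the limit of > 100000 nM in this assay, at which 2 of the 4 values shown sit.

The compounds shown leave open whether the kind of halogen or its place on the phenyl ring matters, which 4-chlorophenyl could help settle. On these data alone, how a phenyl ring carrying an amine or a carboxylic acid would behave also remains open.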